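Furan-3-yl in place of furan-2-yl on a shared core

This account rests on a few compounds, and the source may have more. Where it says the series, first, only, none or still open, it means among the compounds named here.

In a functional assay on HL-60 cells (Homo sapiens) for cytotoxicity, read by XTT assay, with a stated time of 3 days (a higher number here means a weaker inhibitor, a lower number a stronger inhibitor), two compounds have been tested so far
- Compound 1 `OC[C@H]1O[C@@H](n2cc(F)c3c(-c4ccco4)ncnc32)[C@H](O)[C@@H]1O` gives 1200 nM as its result
- Compound 2 `OC[C@H]1O[C@@H](n2cc(F)c3c(-c4c[nH]cn4)ncnc32)[C@H](O)[C@@H]1O` stands at "not determined" (no result reported), with no reported result

Going by the values given here, compound 1 therefore holds the only number available. Among the compounds with values here, it cannot be ranked against any other compound, and no step between two measured compounds exists to guide a forecast.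

Compound 3 `OC[C@H]1O[C@@H](n2cc(F)c3c(-c4ccoc4)ncnc32)[C@H](O)[C@@H]1O` has not yet been measured. It contains the same atoms as compound 1, joined differently. The change furan-3-yl in place of furan-2-yl on an aromatic carbon puts furan-3-yl in place of furan-2-yl on an aromatic carbon of the shared core, while the rest of the structure stays as it is.

Within the data shown here, with compound 1 at 1200 nM as the sole reference, and no measured pair of this kind to read from, no step beyond the scatter is expected in this assay in either direction. The estimated step of a 1.2-fold lower number from compound 1 to compound 3 (0.08 log units; within the scatter) is accordingly expected to stay small, although a single reference leaves the range wide. Compound 3 is expected at about 1000 nM in this measurement, with an estimated range from 300 nM to 3500 nM until the result is known.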

Compound 3, half-maximal inhibitory concentration: 2000 nM
Estimate against measurement, compound 3: 2.0-fold (0.30 log units) below; low and high end bracket the measured number.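

In this assay, going by these compounds alone, the exchange of furan-2-yl for furan-3-yl on an aromatic carbon of the shared core gives a 1.7-fold higher number from compound 1 to compound 3 (0.22 log units; within the scatter), the first step between two measured compounds in this set. Within the data shown here, the single value of compound 1 could not show how much the point of attachment of the furan matters, whereas this pair shows that the two isomers, with the same atoms and the same counts of hydrogen-bond donors and acceptors, cannot be told apart in this measurement. Nothing measured here offers an explanation for this result.

From the compounds shown here alone, the pair covers only two furan attachments at this one aromatic carbon, and compound 2 has no result that could extend the comparison, so it remains open whether a different group there, such as an amine, a methoxy group or a carboxylic acid, would produce a step beyond the scatter. Going by these compounds, it also remains open whether the same exchange of furan-2-yl for furan-3-yl would give a similar step on a core with another group in place of the fluorine.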